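One Chlorine Less: From Compound 2 to Compound 4

A few compounds are considered here, and "the series" means these few. Any claim that something is new, unique, unknown or untested is made for them only; others in the source may bear on it.

Three compounds that share a core have been measured in a physicochemical assay for lipophilicity, measured as octanol-water partition; a lower number here means a more polar compound, a higher number a more lipophilic compound:

compound 1, `O=C(COc1cccc2ccccc12)N/N=C/c1ccccc1[N+](=O)[O-]`: 3.97
compound 2, `O=C(COc1cccc2ccccc12)N/N=C/c1ccc(Cl)cc1`: 4.54
compound 3, `C/C(=N\NC(=O)COc1cccc2ccccc12)c1ccc([N+](=O)[O-])cc1`: 3.37

Among these three numbers compound 2 stands highest. Its nearest neighbour is compound 1, whose value lies lower by a margin beyond the usual scatter; furthest away is compound 3, whose value lies lower still, again beyond the scatter. For the measured compounds named here, none of the three measured compounds differs from another in a single place, so no measured step is available to lean on.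

The compound that follows is compound 4, `O=C(COc1cccc2ccccc12)N/N=C/c1ccccc1`, which has not yet been measured. It differs from compound 2 in one place:

hydrogen in place of chloro on an aromatic carbon

Because compound 2 gives 4.54 in this assay and the change only takes a chloro group away, leaving the rest of the structure untouched, a move toward a more polar reading is expected, and a step of a size beyond the scatter is anticipated rather than none. Compound 4 is expected to give about 3.85 in this assay, with a range from 3.5 to 4.2. This estimate means an expected step of a number 0.69 log units lower from compound 2 to compound 4 (beyond the scatter) in this assay.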

Compound 4, partition coefficient: 4.02
For compound 4 the middle estimate is 0.17 log units below the measured one; measured number inside the range.
By their numbers in this assay, from the lowest: compound 3; then compounds 1 and 4 (each within the scatter of the next); then compound 2.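

The chloro group on an aromatic carbon, para to a large group, now has a measured weight in this assay: the change from 4-chlorophenyl to phenyl gives a number 0.52 log units lower from compound 2 to compound 4 (beyond the scatter) and is a modest step, the first single-place step available in this set. The second single-place comparison reads differently, since taking the nitro group away gives a number 0.05 log units higher from compound 1 to compound 4 (within the scatter) and stays within the scatter. Measured against the same phenyl compound 4, then, taking away chloro moves the number beyond the scatter while taking away nitro does not, although this rests on just these two pairs and is no general rule.

On these data alone, it remains open how other groups on that same aromatic carbon would compare with chloro and with hydrogen, for instance bromo, methoxy, an amine or a carboxylic acid, and whether the chloro step would repeat on a compound carrying the extra methyl group seen in compound 3. Why the two exchanges differ also stays open, as nothing available here speaks to a cause.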